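Replacing a Carboxyphenyl Ester with a Phenylethenyl Ester

A few compounds are considered here, and "the series" means these few. Any claim that something is new, unique, unknown or untested is made for them only; others in the source may bear on it.

Of the compounds shown here, three sharing one core have been tested in a functional assay on B16 cells (Mus musculus) for antiproliferative activity, with a stated time of 72 h; on this read-out higher numbers stand for weaker inhibition and lower numbers for stronger inhibition. Compound 1 `C#CCSc1cnc2ccccc2c1[Se]CC#CCCl` gives 7.1 ug/mL, compound 2 `OCC#CCSc1cnc2ccccc2c1SCC#CCCl` gives 43.4 ug/mL, and compound 3 `O=C(O)c1ccc(C(=O)OCC#CCSc2cnc3ccccc3c2Cl)cc1` gives 53.8 ug/mL. Compound 3 carries the highest of these three numbers; compound 2 sits within the usual scatter of it, while compound 1 lies beyond that scatter on the stronger side. Compound 4 `O=C(/C=C/c1ccccc1)OCC#CCSc1cnc2ccccc2c1Cl` has not yet been measured in this assay. It differs from compound 3 in one place: 2-phenylethenyl in place of 4-carboxyphenyl on a carbonyl carbon. Among the compounds with values here, no measured pair shows this change, so its effect can only be guessed. The expected step of a 1.5-fold lower number from compound 3 to compound 4 (0.19 log units; within the scatter) is small, toward a somewhat lower number if anything, and not beyond the scatter. Compound 4 is therefore estimated at 35 ug/mL, within a range from 12 ug/mL to 100 ug/mL.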

Compound 4, concentration for 50% inhibition: 11.4 ug/mL
Compound 4: middle estimate off by 3.1-fold (0.49 log units), on the high side, outside the stated range (below it).
By their numbers in this assay, from the lowest: compounds 1 and 4 (each within the scatter of the next); then compounds 2 and 3 (each within the scatter of the next).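

In this assay, the group on this ester carbonyl carbon clearly matters: 2-phenylethenyl in place of 4-carboxyphenyl gives a 4.7-fold lower number from compound 3 to compound 4 (0.67 log units; beyond the scatter). Within the data shown here, this is the first change that can be read at a single place, and its size goes beyond the usual scatter. Nothing measured here explains the step. The compounds shown cannot tell whether the step comes from losing the carboxylic acid or from gaining the double bond of the new group. A 2-phenylethyl group on the same carbonyl carbon would help to separate the two.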